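Benzoxazole anilides with piperazine acetamides: methyl removal

This account rests on a few compounds, and the source may have more. Where it says the series, first, only, none or still open, it means among the compounds named here.

Compound 3 `Cc1cc(-c2nc3ccccc3o2)ccc1NC(=O)CN1CCN(CCN(C)C)CC1` gives 42700 nM in a functional assay on C6 cells (Rattus norvegicus) for cytotoxicity, read by MTT assay, with a stated time of 24 h (a higher number here means a weaker inhibitor, a lower number a stronger inhibitor), the highest of the three numbers measured. Compound 2 `CN(C)CCCN1CCN(CC(=O)Nc2ccc(-c3nc4ccccc4o3)cc2)CC1` gives 42300 nM, the nearest number and within the scatter of compound 3. Compound 1 `CN(C)CCN1CCN(CC(=O)Nc2ccc(-c3nc4cc(F)ccc4o3)cc2)CC1` gives 4390 nM, the furthest, with a number well below that of compound 3 and beyond the scatter. Compound 4 `CN(C)CCN1CCN(CC(=O)Nc2ccc(-c3nc4ccccc4o3)cc2)CC1` is not yet measured. It differs from compound 3 by hydrogen in place of methyl on an aromatic carbon. For the measured compounds named here, no step between measured compounds covers this change. Compound 4 is expected to move toward a lower number with a step of a 2.1-fold lower number from compound 3 to compound 4 (0.33 log units; beyond the scatter), of moderate size, around the edge of the scatter. Compound 4 is thus estimated at 20000 nM, with a range from 5000 nM to 60000 nM.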

Compound 4, half-maximal inhibitory concentration: 7010 nM
Compound 4: the middle estimate sits 2.9-fold (0.46 log units) above what was measured; measured number inside the range.
By their numbers in this assay, from the lowest: compounds 1 and 4 (each within the scatter of the next); then compounds 2 and 3 (each within the scatter of the next).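

In this assay, hydrogen in place of methyl on the aromatic carbon ortho to a large group gives a 6.1-fold lower number from compound 3 to compound 4 (0.78 log units; beyond the scatter), so this position does bear on the number. Dimethylamino in place of (dimethylamino)methyl on the chain gives a 6.0-fold lower number from compound 2 to compound 4 (0.78 log units; beyond the scatter), which shows the chain also matters, while hydrogen in place of fluoro on the core gives a 1.6-fold higher number from compound 1 to compound 4 (0.20 log units; within the scatter) and stays within the scatter. No measurement shown gives a cause for these steps.

Going by these compounds, whether chloro or methoxy on this aromatic carbon would behave as methyl does remains open. So does the effect of a longer chain beyond the (dimethylamino)methyl extension.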